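This account rests on a few compounds, and the source may have more. Where it says the series, first, only, none or still open, it means among the compounds named here.

Working notes on the series. In a functional assay on IMR-32 cells for inhibition of Voltage-dependent N-type calcium channel subunit alpha-1B (Homo sapiens), read by calcium flux (on this read-out higher numbers stand for weaker inhibition and lower numbers for stronger inhibition), compound 1 `CC1=NC(C)=C(C(=O)O)C(c2ccc([N+](=O)[O-])cc2)/C1=C(\O)OC/C=C/c1ccccc1` gives 21000 nM, compound 2 `COC(=O)c1cccc(C2C(C(=O)O)=C(C)N=C(C)/C2=C(/O)OC/C=C/c2ccccc2)c1` gives 4600 nM, and compound 3 `CC1=NC(C)=C(C(=O)O)C(c2cccc(C)c2)/C1=C(\O)OC/C=C/c1ccccc1` gives 1800 nM. Compound 3 stands lowest of the three numbers in this assay: the step of a 2.6-fold lower number from compound 2 to compound 3 (0.41 log units; beyond the scatter) and the step of a 12-fold lower number from compound 1 to compound 3 (1.07 log units; beyond the scatter) both lie beyond the scatter, as does the step of a 4.6-fold lower number from compound 1 to compound 2 (0.66 log units; beyond the scatter).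

Compound 4 `CC1=NC(C)=C(C(=O)O)C(c2cccnc2)/C1=C(\O)OC/C=C/c1ccccc1` is not yet measured in this assay. The change from compound 3 to compound 4 is pyridin-3-yl in place of 3-methylphenyl on a saturated ring carbon. Within the data shown here, the steps that bear on it are the two that lead into compound 3, each of which also exchanged the group on the saturated ring carbon while keeping a ring of carbon only; no measured step exchanges that ring for one with a hetero atom. Those two steps both moved the number downward toward compound 3, so the expectation for compound 4 in this assay is a modest step back upward, a 2.2-fold higher number from compound 3 to compound 4 (0.35 log units; beyond the scatter), with wide uncertainty. The estimate for compound 4 in this assay is 4000 nM, between 1500 nM and 12000 nM.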

Compound 4, half-maximal inhibitory concentration: 24000 nM
The estimate for compound 4 lay 6.0-fold (0.78 log units) below the measured number; measured number outside the range, above it.
By their numbers in this assay, from the lowest: compound 3; then compound 2; then compounds 1 and 4 (each within the scatter of the next).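

In this assay, the first ring with a hetero atom on the saturated ring carbon gives a large step, a 13-fold higher number from compound 3 to compound 4 (1.12 log units; beyond the scatter), so this position does not accept pyridin-3-yl as an equal of 3-methylphenyl. The same ring also compares poorly with 3-(methoxycarbonyl)phenyl, a 5.2-fold higher number from compound 2 to compound 4 (0.72 log units; beyond the scatter), while a 1.1-fold higher number from compound 1 to compound 4 (0.06 log units; within the scatter) lies within the scatter, leaving pyridin-3-yl and 4-nitrophenyl indistinguishable here. No supporting data on the origin of these steps are available.

The step from compound 3 to compound 4 both brings in a ring nitrogen and removes the methyl, and the compounds shown do not separate these two changes. Unsubstituted phenyl and a methyl-bearing pyridine ring on this carbon remain open, as do pyridin-2-yl and pyridin-4-yl.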